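The source may report more compounds than this note shows. Statements on the series, on what has been measured and on what is new or still open speak of the compounds shown alone.

Among the compounds with values here, in an in vitro ADME assay on microsomes from liver (Homo sapiens) for metabolic stability, read by LC-MS, tested at 1 uM (on this read-out higher numbers stand for fast clearance and lower numbers for slow clearance), compound 3 `Cc1ccc(S(=O)(=O)N2CCCCC2C)cc1C#Cc1cc(Cl)ccc1OCC(=O)O` gives 89 mL.min-1.g-1, the only true number among the measured compounds. Compound 2 `Cc1ccc(S(=O)(=O)N2CCOCC2)cc1C#Cc1cc(Cl)ccc1OCC(=O)O` gives < 10 mL.min-1.g-1, which is a limit of this assay and not a number. Compound 1 `CN(C)S(=O)(=O)c1ccc(F)c(C#Cc2cc(Cl)ccc2OCC(=O)O)c1` carries dimethylamino on a sulfonyl sulfur and gives < 10 mL.min-1.g-1, which is likewise a limit. Compound 4 `Cc1ccc(S(=O)(=O)N(C)C)cc1C#Cc1cc(Cl)ccc1OCC(=O)O` has not yet been measured. It departs from compound 3 in one place: dimethylamino in place of 2-methylpiperidin-1-yl on a sulfonyl sulfur. In words, this is dimethylamino in place of 2-methylpiperidin-1-yl on a sulfonyl sulfur.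

The measured step that bears most directly on this change is an at least 8.9-fold higher number from compound 2 to compound 3 (0.94 log units; beyond the scatter). It brought in the same 2-methylpiperidin-1-yl, in place of morpholin-4-yl on a sulfonyl sulfur, and it lies beyond the scatter. Removing that group from compound 3 is therefore expected to give a step of similar size in the opposite direction, toward slower clearance in this assay. Compound 1 supports this reading, since it shares the entering group and sits at < 10 mL.min-1.g-1, although its core is not identical to that of compound 4. The expected change is an 8.9-fold lower number from compound 3 to compound 4 (0.95 log units; beyond the scatter). The estimate for compound 4 is 10 mL.min-1.g-1, with an expected range of 5 mL.min-1.g-1 to 25 mL.min-1.g-1.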

Compound 4, intrinsic clearance in microsomes: < 10 mL.min-1.g-1
Compound 4 gave a limit, no number; the forecaster's own chance of this, stated with the estimate: 60%; the middle value sits exactly at the limit.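

In this assay, the change on the sulfonyl sulfur now has a direct reading on the shared core: dimethylamino in place of 2-methylpiperidin-1-yl gives an at least 8.9-fold lower number from compound 3 to compound 4 (0.94 log units; beyond the scatter). Taken with an at least 8.9-fold higher number from compound 2 to compound 3 (0.94 log units; beyond the scatter), it shows that two different groups, one with a ring and one without, each separate from 2-methylpiperidin-1-yl by a step beyond the scatter, so among compounds 2, 3 and 4 only compound 3 gives a true number. The steps from compound 2 to compound 4 and from compound 1 to compound 4 cannot be read, so neither the order of morpholin-4-yl and dimethylamino nor the effect of methyl in place of fluoro on an aromatic carbon can be told, since both ends of each step are limits: the limit of < 10 mL.min-1.g-1 in this assay, at which 3 of the 4 values shown sit.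

The compounds shown leave open whether the faster clearance of compound 3 goes with the six-membered ring itself or with its methyl group, a question that plain piperidin-1-yl on the sulfonyl sulfur would address. They also leave open how far the number can climb as the amine grows, for which diethylamino or pyrrolidin-1-yl would give intermediate cases.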